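Adding a Hydroxy Group to a Weakly Cytotoxic Core

The source may hold more compounds than are shown below. What is called first, only, known or untested is meant among the compounds shown, and "the series" means these compounds.

Measured so far:
- Compound 1, structure `C[C@@H]1C(=O)[C@H]2C[C@]1(O)CC1=C2[C@]2(C)CCC[C@](C)(CO)[C@H]2CC1`: in a functional assay on LoVo cells (Homo sapiens) for cytotoxicity, read by MTT assay, with a stated time of 24 h (a higher number here means a weaker inhibitor, a lower number a stronger inhibitor), compound 1 gives > 50000 nM, which is a limit of the assay and not a number.
- Compound 2, structure `C[C@@H]1C(=O)[C@H]2C[C@]1(O)CC1=C2[C@]2(C)CCCC(C)(C)[C@H]2CC1`: in this assay compound 2 gives > 50000 nM, again a limit of the assay rather than a number.

Compound 2 therefore stands at the edge of what this assay can report, and nothing more precise is known about it. Within the data shown here, the one step between compounds measured so far, a step that the two limits leave unreadable from compound 1 to compound 2, runs between two limits and so cannot be read in size or direction, because of the limit of > 50000 nM in this assay, at which 2 of the 2 values shown sit.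

Compound 3, structure `C[C@@H]1C(=O)[C@H]2C[C@]1(O)CC1=C2[C@]2(C)CCC[C@@](C)(CO)[C@H]2CC1`, has not yet been measured. It differs from compound 2 in one place: hydroxy in place of hydrogen on a saturated chain carbon bound to a saturated ring carbon. Among the measured compounds shown here, the only comparable change in the data is the unreadable step just described, so it gives no direction to expect beyond the scatter. The step that the limit leaves unreadable from compound 2 to compound 3 is therefore expected to be nothing that the assay can resolve. Compound 3 is estimated to give 60000 nM in this assay, within a range of 20000 nM to 200000 nM, most likely reported again only as a limit.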

Compound 3, half-maximal inhibitory concentration: > 50000 nM
Compound 3: a limit, no number (the forecaster's own chance of this, stated with the estimate: 85%); the middle value does not contradict the limit.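

Among these compounds, no step among compound 1, compound 2 and compound 3 can be read in size or direction, because each result is a limit and not a number: the limit of > 50000 nM in this assay, at which 3 of the 3 values shown sit. The compounds shown leave open whether the hydroxy group, or the configuration as drawn that separates compound 1 from compound 3, changes cytotoxicity at all in this assay.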